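A Third Amide Substituent on the Shared Core

The source may hold more compounds than are shown below. What is called first, only, known or untested is meant among the compounds shown, and "the series" means these compounds.

In an assay on isolated protein for inhibition of serine/threonine-protein kinase Chk2 (Homo sapiens), read by HTRF, tested at 10 uM (a higher number here means more inhibition at the concentration tested (going by the name of the read-out), a lower number less inhibition), compound 1 `Cc1cccc(Oc2ccnc(N3CCC[C@H]3C(=O)NCc3cccnc3)n2)c1` gives 4%, and compound 2 `Cc1cccc(Oc2ccnc(N3CCC[C@H]3C(=O)NCCCn3ccnc3)n2)c1` gives 0%; the two sit together, since a number 4 percentage points lower from compound 1 to compound 2 (within the scatter). Compound 3 `COC(=O)C(CO)NC(=O)[C@@H]1CCCN1c1nccc(Oc2cccc(C)c2)n1` has not been measured. It differs from compound 2 by 2-hydroxy-1-(methoxycarbonyl)ethyl in place of 3-(1H-imidazol-1-yl)propyl on an amide-type nitrogen. Going by the values given here, the only measured step that bears on this place, a number 4 percentage points lower from compound 1 to compound 2 (within the scatter), also exchanged the group on the amide-type nitrogen and stayed within the scatter, so an exchange there is expected to leave this assay little altered, a number 3 percentage points higher from compound 2 to compound 3 (within the scatter). Compound 3 is therefore expected to give 3%, within -8% to 14%.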

Compound 3, a percentage reported as inhibition, at one concentration (the size of the read-out at that concentration, not a potency): 3%
Compound 3: the middle estimate sits on the measured number at the digits printed, within the range that was stated.
By their numbers in this assay, from the lowest: compounds 2, 3 and 1 (each within the scatter of the next).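

In this assay the exchange of 3-(1H-imidazol-1-yl)propyl for 2-hydroxy-1-(methoxycarbonyl)ethyl gives a number 3 percentage points higher from compound 2 to compound 3 (within the scatter) and the exchange of (pyridin-3-yl)methyl for the same group gives a number 1 percentage points lower from compound 1 to compound 3 (within the scatter) on the amide-type nitrogen. A group with no ring and with a double bond outside aromatic rings thus reads alike with the two ring-bearing groups at this place. Nothing at hand accounts for this reading. Going by these compounds, whether a carboxylic acid in place of the methyl ester, or a primary amine on the chain, would read alike stays open.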